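The compounds below may be only part of what the source reports. "The series", "measured", "known", "first", "only" and "open" are said of these compounds alone.

Compound 1 `Cc1ccccc1C(=O)Nc1cccc(-c2oc3cc(-c4ccc(F)cc4)ccc3c(=O)c2O)c1` — 4910 nM
Compound 2 `Cc1cc(C(=O)Nc2cccc(-c3oc4cc(-c5ccc(F)cc5)ccc4c(=O)c3O)c2)ccc1F` — 7440 nM
Compound 3 `COc1ccc(C(=O)Nc2cccc(-c3oc4cc(-c5ccc(F)cc5)ccc4c(=O)c3O)c2)c(F)c1` — 17600 nM

All three compounds share one core and differ only in the aryl group on the carbonyl carbon of the amide. In a functional assay on MDA-MB-231 cells (Homo sapiens) for antiproliferative activity, read by CCK-8 assay, with a stated time of 72 h (on this read-out higher numbers stand for weaker inhibition and lower numbers for stronger inhibition), compound 3 gives 17600 nM, the highest number of the three. The change toward it was a 3.6-fold higher number from compound 1 to compound 3 (0.55 log units; beyond the scatter) and a 2.4-fold higher number from compound 2 to compound 3 (0.37 log units; beyond the scatter), while the other pair showed a 1.5-fold higher number from compound 1 to compound 2 (0.18 log units; within the scatter). Varying this aryl group therefore moved the read-out only modestly across the measured set.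

Compound 4 `O=C(Nc1cccc(-c2oc3cc(-c4ccc(F)cc4)ccc3c(=O)c2O)c1)c1ccc([N+](=O)[O-])cc1` carries 4-nitrophenyl in place of 2-fluoro-4-methoxyphenyl on a carbonyl carbon. Going by the values given here, no measured step introduces a nitro group, so none bears on this change directly; the three measured steps only show how wide the window is when the aryl on the carbonyl carbon is exchanged. Since compound 3 holds the highest number, and the measured exchanges spanned a modest range, the step of a 2.2-fold lower number from compound 3 to compound 4 (0.34 log units; beyond the scatter) is expected to return compound 4 toward the middle of that window, a modest move to a lower number, though a step within the scatter would not be surprising. Compound 4 is estimated at 8000 nM in this assay, with a range from 3000 nM to 20000 nM.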

Compound 4, half-maximal inhibitory concentration: 14700 nM
The estimate for compound 4 lay 1.8-fold (0.26 log units) below the measured number; the measured number falls inside the stated range.
By their numbers in this assay, from the lowest: compounds 1, 2, 4 and 3 (each within the scatter of the next, the first and the last beyond it).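

Exchanging the aryl group on the carbonyl carbon for 4-nitrophenyl, which brings in nitrogen and drops both fluorine and methoxy, gives no readable change in this assay, with a 1.2-fold lower number from compound 3 to compound 4 (0.08 log units; within the scatter) and a 2.0-fold higher number from compound 2 to compound 4 (0.30 log units; within the scatter), both within the scatter. Going by these compounds alone, the only step of the three beyond the scatter is a 3.0-fold higher number from compound 1 to compound 4 (0.48 log units; beyond the scatter), a modest one, and it cannot be assigned to the nitro group or the methyl group alone, since the whole aryl group is exchanged. Nothing available here explains why the 4-nitrophenyl and 2-fluoro-4-methoxyphenyl groups read so alike.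

The compounds shown leave open whether any aryl group at this place can bring the number far below that of compound 1, since all four aryl groups carry substituents and the plain phenyl group is not among them. As far as these compounds go, it also remains open whether a ring bearing an amine or a carboxylic acid, or a longer alkyl chain in place of the aryl group, would stay within this modest window or move the read-out well outside it.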